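The source may hold more compounds than are shown below. What is called first, only, known or untested is meant among the compounds shown, and "the series" means these compounds.

Compounds measured in an ADME assay on HepG2 cells (Homo sapiens) for cytotoxicity, read by sulforhodamine B assay, with a stated time of 48 h; a lower number here means that less compound is tolerated, a higher number that more compound is tolerated:
- Compound 1, `COc1nc2ccccc2cc1/C=C/c1noc(-c2ccc(F)cc2)n1`, gives a limit of > 230000 nM.
- Compound 2, `COc1nc2ccccc2cc1/C=C/c1noc(-c2ccccc2Br)n1`, gives a limit of > 195000 nM.

Compound 2 stands at a limit in this assay, not at a number. Among the compounds with values here, the only measured step, from compound 1 to compound 2, is a step that the two limits leave unreadable from compound 1 to compound 2, because both of its ends are limits, the limit of > 195000 nM in this assay, at which 1 of the 2 values shown sits, and (the limit of > 230000 nM in this assay, at which 1 of the 2 values shown sits). The change now considered is 3-methylphenyl in place of 2-bromophenyl on an aromatic carbon, giving compound 3, `COc1nc2ccccc2cc1/C=C/c1noc(-c2cccc(C)c2)n1`. Within the data shown here, the one step that bears on it is unreadable, so no size can be carried over; the two limits only show that neither aryl group brought the value into the readable range of this assay. Compound 3 is therefore expected to show a step that the limit leaves unreadable from compound 2 to compound 3, most likely again as a limit rather than a number. The estimate for compound 3 in this assay is 200000 nM, with a range from 100000 nM to 400000 nM.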

Compound 3, half-maximal cytotoxic concentration: > 230000 nM
Compound 3: no number, only a limit; the forecaster's own chance of this, stated with the estimate: 80%; at least 1.1-fold (0.06 log units) between middle value and limit.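

In this assay, within the data shown here, compound 1, compound 2 and compound 3 all stand at limits, so no step among them can be read. The compounds shown leave open whether any aryl group on the shared core would give a readable number in this assay.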